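This account rests on a few compounds, and the source may have more. Where it says the series, first, only, none or still open, it means among the compounds named here.

Working notes on the benzyl-ether series around a shared core.

Compound 1 `Cc1ccccc1COc1ccc(-c2cc(CN3CCN(Cc4ccc(C(F)(F)F)cc4)CC3)no2)cc1` gives 6800 nM in a functional assay on Mahlavu cells (Homo sapiens) for antiproliferative activity, read by sulforhodamine B assay, with a stated time of 72 h; a higher number here means a weaker inhibitor, a lower number a stronger inhibitor. Compound 2 `Cc1cccc(COc2ccc(-c3cc(CN4CCN(Cc5ccc(C(F)(F)F)cc5)CC4)no3)cc2)c1` gives 2500 nM in this assay, and compound 3 `Fc1ccccc1COc1ccc(-c2cc(CN3CCN(Cc4ccc(C(F)(F)F)cc4)CC3)no2)cc1` gives 3100 nM in this assay. Among the three numbers compound 3 stands second highest: the nearest is compound 2, with a 1.2-fold higher number from compound 2 to compound 3 (0.09 log units; within the scatter), and the furthest is compound 1, with a 2.2-fold lower number from compound 1 to compound 3 (0.34 log units; beyond the scatter). The remaining step is a 2.7-fold lower number from compound 1 to compound 2 (0.43 log units; beyond the scatter).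

Compound 4 `COc1cc(COc2ccc(-c3cc(CN4CCN(Cc5ccc(C(F)(F)F)cc5)CC4)no3)cc2)cc(OC)c1OC` has not yet been measured. Its change from compound 3 is 3,4,5-trimethoxyphenyl in place of 2-fluorophenyl on a saturated chain carbon bound to an oxygen on an aromatic ring. Within the data shown here, all three measured steps alter the same ring on the saturated chain carbon bound to the ring oxygen, and none goes beyond modest size; none of them introduces methoxy groups, so the new ring has no direct precedent here. The expectation is therefore a step of modest size at most, with no clear direction, a 1.0-fold lower number from compound 3 to compound 4 (0.01 log units; within the scatter). Compound 4 is estimated at 3000 nM, with a range from 1000 nM to 10000 nM in this assay.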

Compound 4, half-maximal inhibitory concentration: 5800 nM
Beside the measured number, compound 4's estimate is 1.9-fold (0.29 log units) below it; the measured number falls inside the stated range.
By their numbers in this assay, from the lowest: compounds 2, 3, 4 and 1 (each within the scatter of the next, the first and the last beyond it).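

This position accepts 3,4,5-trimethoxyphenyl, with 12 heavy atoms and 3 hydrogen-bond acceptors against 7 heavy atoms and 0 acceptors in 2-fluorophenyl, with no step beyond the scatter against that ring (a 1.9-fold higher number from compound 3 to compound 4 (0.27 log units; within the scatter)) or against 2-methylphenyl (a 1.2-fold lower number from compound 1 to compound 4 (0.07 log units; within the scatter)). Among these compounds, the only step beyond the scatter for this change is the one against 3-methylphenyl (a 2.3-fold higher number from compound 2 to compound 4 (0.37 log units; beyond the scatter)), and it is modest, so in this assay all steps at this position remain modest at most, even with three methoxy groups on the ring. Nothing at hand explains these steps.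

Open, on these data alone, is whether a single methoxy group on this ring would give a similar number to the three together. Also open, as far as these compounds go, is how a ring carrying a dimethylamino group or a carboxylic acid would behave at this position.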